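Nitro to hydrogen on the tert-butyl member of the series

The source may report more compounds than this note shows. Statements on the series, on what has been measured and on what is new or still open speak of the compounds shown alone.

In a functional assay on U-251 cells (Homo sapiens) for inhibition, read by sulforhodamine B assay, with a stated time of 72 h (on this read-out higher numbers stand for an effect only at larger amounts of compound and lower numbers for an effect already at smaller amounts), compound 1 `CSc1ccc(C(=O)/C=C/c2ccc([N+](=O)[O-])o2)cc1` gives 14200 nM, compound 2 `CC(C)(C)c1ccc(C(=O)/C=C/c2ccc([N+](=O)[O-])o2)cc1` gives 44500 nM and compound 3 `O=C(/C=C/c1ccc([N+](=O)[O-])o1)c1ccc(N2CCCC2)cc1` gives 35900 nM. Compound 2 sits at the upper end of these numbers, with a 3.1-fold higher number from compound 1 to compound 2 (0.50 log units; beyond the scatter) and a 1.2-fold lower number from compound 2 to compound 3 (0.09 log units; within the scatter).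

Compound 4 `CC(C)(C)c1ccc(C(=O)/C=C/c2ccco2)cc1` keeps the tert-butyl group of compound 2 and differs at one place: hydrogen in place of nitro on an aromatic carbon. Going by the values given here, all three measured compounds carry the nitro group, so no measured step covers this change. The measured steps only exchange tert-butyl, methylsulfanyl and pyrrolidin-1-yl, and they offer a rough scale at best. The largest of them is a 3.1-fold higher number from compound 1 to compound 2 (0.50 log units; beyond the scatter). A change at the nitro position is expected to move the number at least that far, towards a higher number, though this is a judgement with no direct support from the series. The expected step is a 2.0-fold higher number from compound 2 to compound 4 (0.31 log units; beyond the scatter). For compound 4 the estimated value is 90000 nM, with an expected range of 40000 nM to 200000 nM.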

Compound 4, half-maximal effective concentration: 16400 nM
Estimate against measurement, compound 4: 5.5-fold (0.74 log units) above; measured number below the stated range.
By their numbers in this assay, from the lowest: compounds 1 and 4 (each within the scatter of the next); then compounds 3 and 2 (each within the scatter of the next).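

On the five-membered aromatic ring with 1 oxygen, the nitro group is not required for an effect in this assay when tert-butyl is held constant: hydrogen in place of nitro gives a 2.7-fold lower number from compound 2 to compound 4 (0.43 log units; beyond the scatter). Going by these compounds alone, this is the first step at this position, as the earlier steps exchanged only tert-butyl, methylsulfanyl and pyrrolidin-1-yl while nitro stayed in place. No measurement shown here accounts for the lower number after nitro leaves.

As far as these compounds go, it remains open whether hydrogen in place of nitro gives a step of similar direction and size with the methylsulfanyl group of compound 1 or the pyrrolidin-1-yl group of compound 3. Also open, from the compounds shown here alone, is how another group at this place, such as an amine or a carboxylic acid, would compare with nitro and hydrogen.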